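The compounds below may be only part of what the source reports. "The series", "measured", "known", "first", "only" and "open" are said of these compounds alone.

Within the data shown here, in a functional assay on A549 cells (Homo sapiens) for inhibition, read by MTT assay, with a stated time of 72 h (a higher number here means a weaker inhibitor, a lower number a stronger inhibitor), compound 1 `CC(C)CCN(CCCCCCC(=O)NO)c1ncc(C(=O)NCc2cccnc2)s1` gives 19000 nM, the higher of the two numbers available so far. Compound 2 `O=C(/C=C/c1ccc(CN(Cc2ccc(F)cc2)c2ncc(C(=O)NCCCn3ccnc3)s2)cc1)NO` gives 2700 nM in this assay, but it differs from compound 1 in more than one place, so no single change can be read from that gap. The next compound, compound 3 `CC(C)CCN(CCCCCCC(=O)NO)c1ncc(C(=O)NCCCn2ccnc2)s1`, keeps the core and chains of compound 1 and alters only the amide side: 2-(1H-imidazol-1-yl)ethyl in place of pyridin-3-yl on a saturated chain carbon bound to an amide-type nitrogen. The same difference, cut one bond further out, is (pyridin-3-yl)methyl to 3-(1H-imidazol-1-yl)propyl, the group also carried by compound 2 with its 2700 nM. Among the measured compounds shown here, no measured pair isolates this change, so the expectation is loose. The estimated step of a 1.6-fold lower number from compound 1 to compound 3 (0.20 log units; within the scatter) leans towards a lower number but is expected to stay within the scatter. For compound 3, the estimated value in this assay is 12000 nM, with an expected range of 4000 nM to 30000 nM.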

Compound 3, half-maximal inhibitory concentration: 5200 nM
For compound 3 the middle estimate is 2.3-fold (0.36 log units) above the measured one; the range from low to high includes it.
By their numbers in this assay, from the lowest: compounds 2 and 3 (each within the scatter of the next); then compound 1.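

With the core and chains held fixed, 2-(1H-imidazol-1-yl)ethyl in place of pyridin-3-yl on a saturated chain carbon bound to an amide-type nitrogen gives a 3.7-fold lower number from compound 1 to compound 3 (0.56 log units; beyond the scatter) in this assay as the only difference. This position alone can therefore shift the number beyond the scatter, which the gap between compound 1 and compound 2, differing in more than one place, could not show. Nothing at hand gives a cause for this step.

The compounds shown leave open whether the ring or the length of the chain carries the step, since both differ at once in this single change. On these data alone, how a 3-(pyridin-3-yl)propyl group or a simple amine in the same place would compare also remains open.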